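This account rests on a few compounds, and the source may have more. Where it says the series, first, only, none or still open, it means among the compounds named here.

Measured compounds:
compound 1 `COc1ccc(Oc2ccc3c(NCCCNCc4cc(F)ccc4OC)ccnc3c2)cc1` gives 317 10^-6 cm/s in an ADME assay for permeability, using PAMPA, with a stated time of 30 min, at pH 7.4; on this read-out lower numbers stand for lower permeability and higher numbers for higher permeability
compound 2 `COc1cccc(CNCCCNc2ccnc3cc(Cc4cc(C)cc(C)c4)ccc23)c1O` gives 23 10^-6 cm/s
compound 3 `COc1ccc(F)cc1CNCCCNc1ccnc2cc(Cc3cc(C)cc(C)c3)ccc12` gives 23 10^-6 cm/s

Compound 2 stands level with compound 3 at the digits given, the step of no change at the digits printed from compound 2 to compound 3 (within the scatter) lying within the scatter, while compound 1 sits far above both of them. Compound 4 `CCC(CC)c1ccc2c(NCCCNCc3cccc(OC)c3O)ccnc2c1` has not yet been measured in this assay. It differs from compound 2 in one place: pentan-3-yl in place of 3,5-dimethylbenzyl on an aromatic carbon. Within the data shown here, only one measured step touches the same position on the shared core, namely a 14-fold lower number from compound 1 to compound 3 (1.14 log units; beyond the scatter), where 3,5-dimethylbenzyl took the place of 4-methoxyphenoxy and the number fell hard. The step of no change at the digits printed from compound 2 to compound 3 (within the scatter), at the benzyl end of the chain, says nothing about this position. So the position is one where a change of group has already moved the number well beyond the scatter, and compound 4 now carries pentan-3-yl there instead of 3,5-dimethylbenzyl. Among the measured compounds shown here, with only one relevant step, and that one going from an aryl ether to the benzyl group rather than to an alkyl chain, the direction is uncertain; the account expects a moderate rise for compound 4, a 2.2-fold higher number from compound 2 to compound 4 (0.34 log units; beyond the scatter), with a wide band. Compound 4 is estimated at 50 10^-6 cm/s, in the range 15 10^-6 cm/s to 180 10^-6 cm/s.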

Compound 4, apparent permeability: 23 10^-6 cm/s
Compound 4: the middle estimate sits 2.2-fold (0.34 log units) above what was measured; the range from low to high includes it.
By their numbers in this assay, from the lowest: compounds 2, 3 and 4 (each within the scatter of the next); then compound 1.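

In this assay, pentan-3-yl in place of 3,5-dimethylbenzyl on this aromatic carbon gives no change at the digits printed from compound 2 to compound 4 (within the scatter). Among these compounds, until now the only step read at this position was a 14-fold lower number from compound 1 to compound 3 (1.14 log units; beyond the scatter), so a change of group there had been seen only to move the number beyond the scatter; this result shows that a change at the same carbon can also stay within it, even when a group with a six-membered aromatic ring and 9 heavy atoms gives way to one with no ring and 5 heavy atoms. Nothing shown gives a reason for this result or for the contrast between the two steps.

The compounds shown leave open whether the large step at this position belongs to 4-methoxyphenoxy alone, or whether a plain phenoxy group, or a benzyloxy group, on the same carbon would also stand apart from compound 2 and compound 4. They also leave open how an amine such as piperidine, a carboxylic acid or a longer alkyl chain would read there.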